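This account rests on a few compounds, and the source may have more. Where it says the series, first, only, none or still open, it means among the compounds named here.

Values in a functional assay on HCT-15 cells (Homo sapiens) for cytotoxicity, read by ELISA, with a stated time of 4 days; a lower number here means a stronger inhibitor, a higher number a weaker inhibitor:
compound 1 `Clc1ccc(-c2cc(-c3ccco3)cc(-c3ccc(Cl)s3)n2)cc1`: 1080 nM
compound 2 `Clc1ccc(-c2cc(-c3ccoc3)cc(-c3ccc(Cl)s3)n2)cc1`: 640 nM
compound 3 `Clc1ccc(-c2cc(-c3ccco3)nc(-c3ccc(Cl)s3)c2)o1`: > 50000 nM (a limit of the assay, not a number)

Compound 3 stands at a limit: the limit of > 50000 nM in this assay, at which 1 of the 3 values shown sits. Going to compound 4 `Clc1ccc(-c2cc(-c3ccc(Cl)o3)cc(-c3ccc(Cl)s3)n2)cc1` puts 4-chlorophenyl in place of furan-2-yl, next to the ring nitrogen (4-chlorophenyl in place of furan-2-yl on an aromatic carbon). Among the compounds with values here, no measured step covers this exchange. Within the data shown here, the one measured step, a 1.7-fold lower number from compound 1 to compound 2 (0.23 log units; within the scatter), alters only the furan group and lies within the scatter. Compound 4 shares its 4-chlorophenyl and 5-chlorothiophen-2-yl groups with compound 1 and compound 2, and differs from them in its 5-chlorofuran-2-yl group. Its number in this assay is expected to lie near those of compound 1 at 1080 nM and compound 2 at 640 nM. A large fall in the number is therefore expected, an at least 33-fold lower number from compound 3 to compound 4 (1.52 log units; beyond the scatter). Compound 4 is estimated at 1500 nM, with an expected range of 400 nM to 9000 nM.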

Compound 4, half-maximal inhibitory concentration: 25300 nM
Beside the measured number, compound 4's estimate is 17-fold (1.23 log units) below it; measured number outside the range, above it.
By their numbers in this assay, from the lowest: compounds 2 and 1 (each within the scatter of the next); then compound 4. At a limit, above all of these: compound 3.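

In this assay, chloro in place of hydrogen on an aromatic carbon gives a 23-fold higher number from compound 1 to compound 4 (1.37 log units; beyond the scatter), and 5-chlorofuran-2-yl in place of furan-3-yl on an aromatic carbon gives a 40-fold higher number from compound 2 to compound 4 (1.60 log units; beyond the scatter). This place therefore answers strongly to the added chloro, which the exchange of furan-2-yl for furan-3-yl alone did not show. With 4-chlorophenyl in place of furan-2-yl on an aromatic carbon, the change is an at least 1.9-fold lower number from compound 3 to compound 4 (0.29 log units; that floor lies within the scatter) and no more can be read from it. Compound 3 is a limit of the assay, not a number: the limit of > 50000 nM in this assay, at which 1 of the 4 values shown sits.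

Open, going by these compounds, is whether the rise belongs to chloro alone or would also follow a methyl, an amine or a carboxylic acid in its place.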